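A few compounds are considered here, and "the series" means these few. Any claim that something is new, unique, unknown or untested is made for them only; others in the source may bear on it.

Compound 1 `NS(=O)(=O)NNc1nonc1/C(=N/O)Nc1ccc(F)c(Br)c1`, compound 2 `N=S1(=O)CC(Nc2nonc2/C(=N/O)Nc2ccc(F)c(Br)c2)C1` and compound 3 `NS(=O)(=O)CCNc1nonc1/C(=N/O)Nc1ccc(F)c(Br)c1` share one core and differ only in the group carried by the nitrogen on the aromatic ring. In an assay on HeLa cells for inhibition of Indoleamine 2,3-dioxygenase 1 (Homo sapiens), read by spectrophotometry, with a stated time of 24 h (on this read-out higher numbers stand for an effect only at larger amounts of compound and lower numbers for an effect already at smaller amounts), compound 1 gives 101 nM, compound 2 gives 53 nM and compound 3 gives 11 nM. Compound 3 therefore holds the lowest number of the three: a 9.2-fold lower number from compound 1 to compound 3 (0.96 log units; beyond the scatter) and a 4.8-fold lower number from compound 2 to compound 3 (0.68 log units; beyond the scatter), whereas a 1.9-fold lower number from compound 1 to compound 2 (0.28 log units; within the scatter).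

Compound 4 `NS(=O)(=O)CCCNc1nonc1/C(=N/O)Nc1ccc(F)c(Br)c1` has not yet been tested in this assay. It keeps the chain of compound 3 and lengthens it by one link: sulfamoylmethyl in place of sulfamoyl on a saturated chain carbon, two bonds along the chain from a nitrogen on an aromatic ring. For the measured compounds named here, none of the measured steps lengthens a chain in this way; the two that bear on this place, a 9.2-fold lower number from compound 1 to compound 3 (0.96 log units; beyond the scatter) and a 4.8-fold lower number from compound 2 to compound 3 (0.68 log units; beyond the scatter), each exchange one linker for another, and both favour the 2-sulfamoylethyl chain of compound 3 over a shorter group or a ring-bearing one. Whether one further chain carbon keeps that gain cannot be read from these three compounds, so for compound 4 no step beyond the scatter is expected in this assay, although a small loss seems somewhat more likely than a gain. The expected step is a 1.6-fold higher number from compound 3 to compound 4 (0.21 log units; within the scatter). Compound 4 is accordingly estimated at 18 nM, with a range from 6 nM to 60 nM.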

Compound 4, half-maximal effective concentration: 15 nM
Compound 4: the middle estimate sits 1.2-fold (0.08 log units) above what was measured; measured number inside the range.
By their numbers in this assay, from the lowest: compounds 3 and 4 (each within the scatter of the next); then compounds 2 and 1 (each within the scatter of the next).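

In this assay, the first change made along the chain itself stays small (a 1.4-fold higher number from compound 3 to compound 4 (0.13 log units; within the scatter)), so sulfamoylmethyl in place of sulfamoyl on this saturated chain carbon, two bonds along the chain from a nitrogen on an aromatic ring, does not move the number beyond the scatter. The edge over the other groups on the nitrogen therefore does not belong to 2-sulfamoylethyl alone: 3-sulfamoylpropyl also stands clear of them (a 3.5-fold lower number from compound 2 to compound 4 (0.55 log units; beyond the scatter)) and (a 6.7-fold lower number from compound 1 to compound 4 (0.83 log units; beyond the scatter)), both beyond the scatter, though the second of these is a little smaller than the step from compound 1 to compound 3 printed earlier. What lies behind this shared behaviour of the two chains cannot be said, as no measurement here speaks to it.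

The compounds shown leave open how far the chain can grow, since a longer chain such as 4-sulfamoylbutyl might keep the number or lose it. They also leave open whether sulfamoyl itself matters on these chains, or whether a carboxylic acid, a simple amide or an amine carried on the same chain would give a similar number.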